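The source may hold more compounds than are shown below. What is called first, only, known or untested is meant among the compounds shown, and "the series" means these compounds.

Compound 2 `COc1ccc(-c2nc(/N=C(\N)NC3CCCCC3)sc2-c2ccc(OC)cc2)cc1` gives in a functional assay with Oryctolagus cuniculus as the target (a lower number here means a stronger inhibitor, a higher number a weaker inhibitor), only a limit, > 1000 nM, so where it stands among the three measured compounds cannot be fixed; this is the limit of > 1000 nM in this assay, at which 1 of the 3 values shown sits. Compound 1 `COc1ccc(-c2nc(N=C(N)N)sc2-c2ccc(OC)cc2)cc1` gives in this assay 31000 nM. Compound 3 `C/N=C(/NC)Nc1nc(-c2ccc(OC)cc2)c(-c2ccc(OC)cc2)s1` gives in this assay 970 nM. The step of a 32-fold lower number from compound 1 to compound 3 (1.50 log units; beyond the scatter) is large, whereas an at least 1.0-fold lower number from compound 2 to compound 3 (0.01 log units; that floor lies within the scatter) sets only a floor that lies within the scatter. Compound 4 `CCN(CC)C(=O)c1nc(-c2ccc(OC)cc2)c(-c2ccc(OC)cc2)s1` differs from compound 2 by a group of 7 heavy atoms (5 carbon, 1 nitrogen, 1 oxygen; no ring) in place of a group of 10 heavy atoms (7 carbon, 3 nitrogen; one six-membered non-aromatic ring of carbon only), on an aromatic carbon. Among the measured compounds shown here, no measured step puts a diethylcarbamoyl in place of any group on that aromatic carbon, so neither direction nor size can be read from the measured steps. Compound 4 is therefore expected near 5000 nM, within a wide range from 800 nM to 40000 nM. The step that the limit leaves unreadable from compound 2 to compound 4 is thus only an estimate.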

Compound 4, half-maximal inhibitory concentration: < 10 nM
Compound 4: a limit, no number (the forecaster's own chance of this, stated with the estimate: 50%); middle value at least 500-fold (2.69 log units) away from the limit.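

The result for compound 4 is a limit, not a number. Even so, in this assay putting diethylcarbamoyl on this aromatic carbon gives an at least 100-fold lower number from compound 2 to compound 4 (2.00 log units; beyond the scatter), an at least 97-fold lower number from compound 3 to compound 4 (1.98 log units; beyond the scatter) and an at least 3100-fold lower number from compound 1 to compound 4 (3.49 log units; beyond the scatter). So a group with a carbonyl and no hydrogen-bond donors can take this position and give far stronger inhibition than any of the three groups before it.

From the compounds shown here alone, how much of this comes from the carbonyl and how much from the two ethyl groups remains open; a carboxylic acid or a dimethylcarbamoyl group here would help to separate them. Going by these compounds, the true value of compound 4 also remains open.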